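This account rests on a few compounds, and the source may have more. Where it says the series, first, only, none or still open, it means among the compounds named here.

Among the compounds with values here, in a physicochemical assay for solubility, at pH 7.4 (on this read-out higher numbers stand for higher solubility and lower numbers for lower solubility), compound 1 (`NS(=O)(=O)c1ccc(S(=O)(=O)CCCO)c([N+](=O)[O-])c1`) gives 800 ug/mL and compound 2 (`COC(=O)c1cc(S(N)(=O)=O)ccc1S(=O)(=O)CCCO`) gives 14000 ug/mL, which puts compound 2 at the higher of the only two numbers so far. Compound 3 (`Nc1cc(S(N)(=O)=O)ccc1S(=O)(=O)CCCO`) is not yet measured. It carries amino in place of methoxycarbonyl on an aromatic carbon, ortho to a (3-hydroxypropyl)sulfonyl group and meta to a sulfamoyl group: amino in place of methoxycarbonyl on an aromatic carbon. Within the data shown here, one measured step bears on this change: an 18-fold higher number from compound 1 to compound 2 (1.24 log units; beyond the scatter), a large step at the same aromatic carbon, with methoxycarbonyl in place of nitro. It shows that a swap at this carbon can move this assay well beyond the scatter, but it says nothing direct about amino, which has no measurement in the series. With compound 2 at 14000 ug/mL as the upper of two numbers, a fall is the likelier direction, and a step somewhat smaller than the measured one is expected. The expected change is a 4.7-fold lower number from compound 2 to compound 3 (0.67 log units; beyond the scatter). For compound 3 the estimate is 3000 ug/mL, with a range of 800 ug/mL to 12000 ug/mL.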

Compound 3, solubility: 8400 ug/mL
Compound 3: the middle estimate sits 2.8-fold (0.45 log units) below what was measured; the range from low to high includes it.
By their numbers in this assay, from the lowest: compound 1; then compounds 3 and 2 (each within the scatter of the next).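

In this assay the swap of methoxycarbonyl (4 heavy atoms) for amino (1 heavy atom) at this aromatic carbon gives a 1.7-fold lower number from compound 2 to compound 3 (0.22 log units; within the scatter), so the large gain seen earlier does not belong to methoxycarbonyl alone. The same carbon with amino in place of nitro gives an 11-fold higher number from compound 1 to compound 3 (1.02 log units; beyond the scatter), a step of the same large class as an 18-fold higher number from compound 1 to compound 2 (1.24 log units; beyond the scatter), which leaves compound 1 as the one that stands apart from the other two. Across this pair, neither the count of heavy atoms nor the change from 0 to 1 hydrogen-bond donor separates compound 2 and compound 3 beyond the scatter in this assay. No measurement here accounts for the result or for the position of compound 1.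

Three groups at one carbon cannot show whether a carboxylic acid, a nitrile or a methylamino group would fall with nitro or with amino and methoxycarbonyl. Also open, going by these compounds, is whether these steps hold with a shorter chain on the sulfonyl group in place of the 3-hydroxypropyl chain, or with a substituted sulfonamide nitrogen in place of the sulfamoyl group.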